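The compounds below may be only part of what the source reports. "The series", "measured", "known", "first", "only" and "open" are said of these compounds alone.

This account follows three thioureas that have been measured for cytotoxicity and a fourth that has not. Compound 1 `CCCCc1ccc(NC(=S)Nc2cccc(C(F)(F)F)c2)c(C)c1`, compound 2 `CC[C@H]1CC[C@H](c2ccc(NC(=S)Nc3cccc(C(F)(F)F)c3)cc2)CC1` and compound 3 `O=C(NC(=S)Nc1cccc(C(F)(F)F)c1)[C@H]1C[C@@H]2CC[C@H]1C2` share a core and were assessed in an ADME assay on MT4 cells (Homo sapiens) for cytotoxicity; on this read-out higher numbers stand for lower toxicity in this test and lower numbers for higher toxicity in this test. In this assay compound 1 gives 43000 nM, compound 2 gives 39000 nM and compound 3 gives 42000 nM. Compound 2 carries the lowest of the three numbers, yet its distance to compound 3 and to compound 1 lies within the usual scatter, so the three cannot be set in any order on this read-out. Compound 4 `O=[N+]([O-])c1ccc(NC(=S)Nc2cccc(C(F)(F)F)c2)cc1` differs from compound 2 in a single place: nitro in place of 4-ethylcyclohexyl on an aromatic carbon. Among the measured compounds shown here, no step between measured compounds is recorded, so the size of this change in this assay can only be judged from the three numbers, which sit close together despite quite different structures. Compound 4 is therefore expected to give 38000 nM, with a range from 15000 nM to 95000 nM. For compound 4 the expected step is a 1.0-fold lower number from compound 2 to compound 4 (0.01 log units; within the scatter), that is, none beyond the scatter in either direction.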

Compound 4, half-maximal cytotoxic concentration: 9200 nM
Estimate against measurement, compound 4: 4.1-fold (0.62 log units) above; the measured number lies below the stated range.
By their numbers in this assay, from the lowest: compound 4; then compounds 2, 3 and 1 (each within the scatter of the next).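

In this assay, among the compounds shown here, nitro in place of 4-ethylcyclohexyl on an aromatic carbon, para to a large group, gives a 4.2-fold lower number from compound 2 to compound 4 (0.63 log units; beyond the scatter) and so provides the first step beyond the scatter in this set. For the compounds shown here, the place therefore is not indifferent to the group it carries on this read-out, a point that the closely spaced numbers of the earlier compounds, with no single-place step among them, could not establish. The change removes a ring of eight carbon atoms with two defined stereocentres and brings in a smaller group with two hydrogen-bond acceptors, but nothing measured here accounts for the lower number.

The compounds shown leave open whether the lower number goes with the arrival of nitro or with the departure of 4-ethylcyclohexyl. An amine, a nitrile or a short chain such as ethyl on the same aromatic carbon would help to separate these two readings.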